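This account rests on a few compounds, and the source may have more. Where it says the series, first, only, none or still open, it means among the compounds named here.

Three compounds sharing a six-membered aromatic ring with one nitrogen have been tested in an assay on isolated protein for inhibition of DNA topoisomerase 1 (Homo sapiens), with a stated time of 30 min, tested at 100 uM; on this read-out lower numbers stand for less inhibition and higher numbers for more inhibition at the one concentration tested (going by the name of the read-out). In this assay compound 1 `Clc1cccc(-c2cc(-c3ccoc3)cc(-c3ccc(Cl)s3)n2)c1` gives 2.1%, and compound 2 `Clc1ccc(-c2cc(-c3ccoc3)cc(-c3ccc(Cl)s3)n2)cc1` gives 2.3%. The only difference between the two is 4-chlorophenyl in place of 3-chlorophenyl on an aromatic carbon, and the measured step is a number 0.2 percentage points higher from compound 1 to compound 2 (within the scatter). Compound 3 `Cc1ccsc1-c1cc(-c2ccc(Cl)o2)cc(-c2cccc(Cl)c2)n1` gives 5.9% in this assay; its core carries other groups than the core of compound 1, and the difference between the two cores is not broken down here.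

Compound 4 `Cc1ccsc1-c1cc(-c2ccc(Cl)o2)cc(-c2ccc(Cl)cc2)n1` has not yet been measured in this assay. It differs from compound 3 by 4-chlorophenyl in place of 3-chlorophenyl on an aromatic carbon, the same kind of change as that between compound 1 and compound 2, though the surroundings are not identical: in compound 1 the position is meta to a 5-chlorothiophen-2-yl group and meta to a furan-3-yl group, whereas in compound 3 it is meta to a 3-methylthiophen-2-yl group and meta to a 5-chlorofuran-2-yl group. The expected step is a number 0.1 percentage points higher from compound 3 to compound 4 (within the scatter), resting on the earlier step of a number 0.2 percentage points higher from compound 1 to compound 2 (within the scatter) that the same kind of change produced. Compound 4 is therefore estimated to give 6%, with a likely range from -4% to 16%.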

Compound 4, a percentage reported as inhibition, at one concentration (the size of the read-out at that concentration, not a potency): 5.1%
Compound 4: the middle estimate sits 0.9 percentage points above what was measured; the measured number falls inside the stated range.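

In this assay, putting 4-chlorophenyl in place of 3-chlorophenyl on the core of compound 3 gives a number 0.8 percentage points lower from compound 3 to compound 4 (within the scatter). Set beside the earlier case, the same change shows no difference between the two cores that can be told apart from ordinary repeat variation: the same change on two cores in this assay, a number 0.2 percentage points higher (within the scatter) from compound 1 to compound 2 and a number 0.8 percentage points lower (within the scatter) from compound 3 to compound 4, 1 percentage points apart, within the scatter of two such steps. For the compounds shown here, this shows that, on these two cores, the swap leaves the read-out unchanged within the scatter, but it comes from only two pairs, each tested at one concentration, and it does not show that the same would hold on a core giving much more inhibition, or on other cores.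

All four compounds carry a chlorophenyl group at this place, so the compounds shown leave open what an amine, a hydroxyl or a carboxylic acid on that phenyl ring would do in this assay. They also leave open whether any such group would lift the read-out clear of the scatter.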